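The compounds below may be only part of what the source reports. "The series", "measured", "known", "first", "only" and "open" are said of these compounds alone.

Compound 1 `COc1cccc(CNCc2c(C(=O)O)n(Cc3ccc(F)cc3)c3ccccc23)c1`: in a functional assay on Bel-7402 cells (Homo sapiens) for antiproliferative activity, read by MTT assay, with a stated time of 72 h (a lower number here means a stronger inhibitor, a higher number a weaker inhibitor), compound 1 reaches only the assay limit, > 50000 nM.
Compound 2 `COc1ccc(Cn2c(C(=O)O)c(CNC(=O)c3cccc(OC)c3)c3ccc(C)cc32)cc1`: in this assay compound 2 likewise reaches only the assay limit, > 50000 nM.

Compound 2 thus stands at the limit, and every value shown sits there (the limit of > 50000 nM in this assay, at which 2 of the 2 values shown sit). Compound 3 `COc1ccc(Cn2c(C(=O)O)c(CNCc3ccc(O)c(OC)c3)c3ccc(C)cc32)cc1` is compound 2 with 4-hydroxy-3-methoxybenzyl in place of (3-methoxyphenyl)carbonyl on an amine nitrogen. Within the data shown here, no step between two measured compounds has been recorded, so the size of this change is open; compound 1, which also carries a benzyl on its amine nitrogen, sits at its limit too. The step from compound 2 to compound 3 is therefore expected to stay within the scatter a step that the limit leaves unreadable from compound 2 to compound 3. Compound 3 is estimated at 60000 nM, between 15000 nM and 200000 nM, most likely again reported only as a limit.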

Compound 3, half-maximal inhibitory concentration: 13300 nM
For compound 3 the middle estimate is 4.5-fold (0.65 log units) above the measured one; measured number below the stated range.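

Among these compounds, on this assay, the change on this amine nitrogen gives the first readable step, an at least 3.7-fold lower number from compound 2 to compound 3 (0.57 log units; beyond the scatter), so this place can shift the number, which the earlier compounds could not show. The true size of the step remains unknown, because compound 2 has no exact value and only a bound can be read: the limit of > 50000 nM in this assay, at which 2 of the 3 values shown sit.

Still open, from the compounds shown here alone, is which part of the change matters: losing the carbonyl or gaining the 4-hydroxy-3-methoxybenzyl. A plain benzyl or a 4-hydroxybenzyl on this nitrogen would help separate the two.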